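From amino to chloro at compound 3

The source may hold more compounds than are shown below. What is called first, only, known or untested is meant among the compounds shown, and "the series" means these compounds.

Values measured so far in an ADME assay on L6 cells (Rattus norvegicus) for cytotoxicity (a lower number here means a stronger inhibitor, a higher number a weaker inhibitor), are these.
Compound 1 `COc1ccc(S(=O)(=O)N2c3ccccc3CCC2C)cc1` gives 5990 nM
Compound 2 `CC1CCc2ccccc2N1S(=O)(=O)c1cccc([N+](=O)[O-])c1` gives 187000 nM
Compound 3 `CC1CCc2ccccc2N1S(=O)(=O)c1ccc(N)cc1` gives 35300 nM

Compound 3 at 35300 nM stands second highest of the three on this scale. Compound 2 at 187000 nM has the higher number and compound 1 at 5990 nM the lower one, with both gaps beyond the scatter.

The next compound to be measured is compound 4 `CC1CCc2ccccc2N1S(=O)(=O)c1ccc(Cl)cc1`, which is reached from compound 3 through chloro in place of amino on an aromatic carbon and amounts to 4-aminophenyl becoming 4-chlorophenyl. The group changes on an aromatic carbon, para to a large group.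

Within the data shown here, one measured step bears on this change, namely a 5.9-fold higher number from compound 1 to compound 3 (0.77 log units; beyond the scatter), where methoxy gives way to amino. That step was modest, and it shows amino carrying the higher number of that pair. Among the measured compounds shown here, no chloro compound has been measured, so this is the only guide, and a weak one. Leaving amino is therefore expected to lower the number, by somewhat less than that step.

The expected change is a 2.9-fold lower number from compound 3 to compound 4 (0.47 log units; beyond the scatter) in this assay as an estimate. Compound 4 is estimated at 12000 nM with an expected range from 4000 nM to 36000 nM in this assay when it is measured.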

Compound 4, half-maximal inhibitory concentration: 20500 nM
Compound 4: the middle estimate sits 1.7-fold (0.23 log units) below what was measured; low and high end bracket the measured number.
By their numbers in this assay, from the lowest: compound 1; then compounds 4 and 3 (each within the scatter of the next); then compound 2.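

In this assay, placing chloro instead of amino on this aromatic carbon, para to a large group, gives a 1.7-fold lower number from compound 3 to compound 4 (0.24 log units; within the scatter) and so leaves the number within the scatter, even though the hydrogen-bond donor and acceptor of amino leave with it. Methoxy now stands apart from both other groups at this place, since the earlier 5.9-fold higher number from compound 1 to compound 3 (0.77 log units; beyond the scatter) is joined by a 3.4-fold higher number from compound 1 to compound 4 (0.53 log units; beyond the scatter) and both steps lie beyond the scatter. No measurement shown here accounts for the lower number with methoxy or for the closeness of amino and chloro.

Three groups at one place cannot show whether ethoxy, hydroxyl or methyl would stay with methoxy or fall in with amino and chloro, nor whether a carboxylic acid or a longer chain would move the number beyond this range. Going by these compounds, the nitro group of compound 2 sits elsewhere on the ring, so it remains open how nitro would compare at this place, and whether the closeness of amino and chloro would hold at that other place.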